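This account rests on a few compounds, and the source may have more. Where it says the series, first, only, none or still open, it means among the compounds named here.

Measured compounds in an ADME assay on microsomes from liver (Homo sapiens) for metabolic stability, tested at 2.5 uM; on this read-out higher numbers stand for fast clearance and lower numbers for slow clearance:
- compound 1, `O=S(=O)(c1cc(F)cc(F)c1)c1cnc2cc(F)ccc2c1-c1ccc(Cl)cc1`, gives 0.03 mL/min
- compound 2, `O=S(=O)(c1cccc(F)c1)c1cnc2cc(F)ccc2c1-c1ccc(Cl)cc1`, gives 0.98 mL/min
- compound 3, `O=S(=O)(c1ccc(F)cc1)c1cnc2ccc(Cl)cc2c1-c1ccc(Cl)cc1`, gives 0.01 mL/min

Compound 3 stands lowest of the three in this assay. Its nearest neighbour is compound 1 and its furthest is compound 2; the difference between the cores of compound 2 and compound 3 is not broken down here. Within the pair that is counted, the change fluoro in place of hydrogen on an aromatic carbon gave a 33-fold lower number from compound 2 to compound 1 (1.51 log units; beyond the scatter).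

Compound 4, `O=S(=O)(c1ccc(F)cc1)c1cnc2c(F)cc(Cl)cc2c1-c1ccc(Cl)cc1`, is not yet measured. It differs from compound 3 by fluoro in place of hydrogen on an aromatic carbon. Within the data shown here, this is the same kind of change as the one from compound 2 to compound 1, not the same change: there the fluoro entered on a ring of carbon only that is not fused, meta to a fluoro group and meta to a large group; here it enters on a ring that is part of a fused system, ortho to a fused ring and meta to a chloro group.

Compound 3 already gives the lowest number of the set, so little room remains for a drop of the size seen from compound 2 to compound 1. For compound 4 the expected step in this assay is no change at the digits printed from compound 3 to compound 4 (within the scatter). Compound 4 is estimated to give 0.01 mL/min, expected between 0.004 mL/min and 0.03 mL/min.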

Compound 4, intrinsic clearance in a liver preparation (reported as CLH), per the amount of preparation that the assay uses: 0.01 mL/min
The estimate for compound 4 equals the measured number at the digits printed; the range from low to high includes it.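

In this assay, fluoro in place of hydrogen on an aromatic carbon gave no change at the digits printed from compound 3 to compound 4 (within the scatter). The size of the step therefore does not carry between these two cores: the same change on two cores in this assay, a 33-fold lower number (1.51 log units; beyond the scatter) from compound 2 to compound 1 and no change at the digits printed (within the scatter) from compound 3 to compound 4, 33-fold (1.51 log units) apart, beyond the scatter of two such steps. Two steps cannot show whether the core or the place of the fluoro sets this difference: the fluoro enters a ring that is not fused in one step and a ring that is part of a fused system in the other.

Open, on these data alone, is whether a group other than a halogen, such as an amine or a methoxy group, would move the number in the same place on the core of compound 3. Also open, as far as these compounds go, is how the change behaves on further cores.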